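This account rests on a few compounds, and the source may have more. Where it says the series, first, only, none or still open, it means among the compounds named here.

Measured in a functional assay on OVCAR-3 cells (Homo sapiens) for antiproliferative activity, read by spectrophotometry, with a stated time of 2 days; on this read-out lower numbers stand for stronger inhibition of growth and higher numbers for weaker inhibition of growth:
- compound 1 `Cc1ccc(Nc2ncc(C(F)(F)F)c(N3Cc4cccc(N(C)S(C)(=O)=O)c4C3)n2)c(Cl)c1`: > 30000 nM
- compound 2 `CN(c1cccc2c1CN(c1nc(Nc3ccc(Nc4ccccc4)cc3)ncc1C(F)(F)F)C2)S(C)(=O)=O`: > 50000 nM

Neither entry is a number. Compound 1 stands only at a limit, > 30000 nM. Compound 2 likewise gives only a limit, > 50000 nM. For the measured compounds named here, no step between measured compounds is available, so the size of any change on this substituent has no direct measure.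

Compound 3 `COc1cc(Nc2ncc(C(F)(F)F)c(N3Cc4cccc(N(C)S(C)(=O)=O)c4C3)n2)cc(OC)c1` keeps the core of compound 1 and carries one change: 3,5-dimethoxyphenyl in place of 2-chloro-4-methylphenyl on a nitrogen on an aromatic ring, (3,5-dimethoxyphenyl in place of 2-chloro-4-methylphenyl on a nitrogen on an aromatic ring). With both measured compounds at limits, no shift beyond the scatter is expected in this assay, and a further limit would be no surprise. The expected step is an at least 1.2-fold lower number from compound 1 to compound 3 (0.07 log units; that floor lies within the scatter). Compound 3 is estimated at 25000 nM, with an expected range of 8000 nM to 50000 nM.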

Compound 3, concentration for 50% growth inhibition: 630 nM
The estimate for compound 3 lay 40-fold (1.60 log units) above the measured number; the whole stated range lies above it.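

In this assay, the group on the aromatic amine nitrogen proves able to move the read-out: 3,5-dimethoxyphenyl in place of 2-chloro-4-methylphenyl gives an at least 47-fold lower number from compound 1 to compound 3 (1.67 log units; beyond the scatter). For the compounds shown here, with the rest of the core of compound 1 unchanged, the substituted phenyl group at this place alone separates a compound with a measured number from one without, which the limits of the earlier compounds could not show. Compound 1 stands at a limit, so the size of this step is a floor and not a measured gap: the limit of > 30000 nM in this assay, at which 1 of the 3 values shown sits.

The change replaces the chlorine, the methyl and both methoxy groups in a single step, so the contribution of each stays unresolved, including whether a single methoxy group would carry the step. Also open, on these data alone, is whether an ethoxy group or an amine on this phenyl ring would keep the read-out at this level.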